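Aminopyridine to methylpyridine: solubility outlook for compound 4

The compounds below may be only part of what the source reports. "The series", "measured", "known", "first", "only" and "open" are said of these compounds alone.

Compound 1 `O=c1ncn(Cc2c(F)cc(F)cc2F)c2ccc(Oc3cccc(-c4ccc5[nH]ccc5c4)c3C(F)(F)F)cc12` and compound 2 `O=c1ncn(Cc2c(F)cc(F)cc2F)c2ccc(Oc3cccc(-c4ccc5[nH]cnc5c4)c3C(F)(F)F)cc12` share their core with compound 3 `Nc1ccc(-c2cccc(Oc3ccc4c(c3)c(=O)ncn4Cc3c(F)cc(F)cc3F)c2C(F)(F)F)cn1`. In a physicochemical assay for solubility, using the shake flask method, with a stated time of 24 h, at pH 2 (on this read-out lower numbers stand for lower solubility and higher numbers for higher solubility), compound 1 reaches only a limit, < 0.1 ug/mL. In this assay compound 2 likewise stops at a limit, < 0.1 ug/mL. Going by the values given here, compound 3 gives 0.3 ug/mL in this assay, the only number among the three. The step that the two limits leave unreadable from compound 1 to compound 2 cannot be sized; the steps of an at least 3.0-fold higher number from compound 1 to compound 3 (0.47 log units; beyond the scatter) and an at least 3.0-fold higher number from compound 2 to compound 3 (0.47 log units; beyond the scatter) are read against (the limit of < 0.1 ug/mL in this assay, at which 2 of the 3 values shown sit). Compound 4 `Cc1ccc(-c2cccc(Oc3ccc4c(c3)c(=O)ncn4Cc3c(F)cc(F)cc3F)c2C(F)(F)F)cn1` differs from compound 3 by methyl in place of amino on an aromatic carbon. Among the compounds with values here, no measured step covers this exchange; the two readable steps concern a different part of the molecule. A step of a 3.0-fold lower number from compound 3 to compound 4 (0.48 log units; beyond the scatter) is expected, downward, possibly back to the limit. Compound 4 is estimated at 0.1 ug/mL, within 0.03 ug/mL to 0.4 ug/mL.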

Compound 4, solubility: 180 ug/mL
Beside the measured number, compound 4's estimate is 1800-fold (3.26 log units) below it, and the stated range ends below it.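

Going by these compounds alone, the group next to the ring nitrogen, para to a large group, matters far more in this assay than the earlier compounds showed: methyl in place of amino gives a 600-fold higher number from compound 3 to compound 4 (2.78 log units; beyond the scatter). Against the earlier aryl groups, 6-methylpyridin-3-yl gives an at least 1800-fold higher number from compound 2 to compound 4 (3.25 log units; beyond the scatter) and an at least 1800-fold higher number from compound 1 to compound 4 (3.25 log units; beyond the scatter). Both of these steps start from a limit of the assay, not a number: the limit of < 0.1 ug/mL in this assay, at which 2 of the 4 values shown sit.

Nothing measured here accounts for a step of this size. Going by these compounds, whether the gain holds with ethyl, methoxy or dimethylamino in the same place stays open.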